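Solubility notes: oxazolidinone series, amide nitrogen substituent

The source may hold more compounds than are shown below. What is called first, only, known or untested is meant among the compounds shown, and "the series" means these compounds.

Measured compounds:
compound 1 `CN(C)S(=O)(=O)NC[C@H]1CN(c2ccc(-n3cc(-c4ccccn4)cn3)c(F)c2)C(=O)O1`: 472000 nM
compound 2 `CNC(=O)[C@H]1CN(c2ccc(-n3cc(-c4ccccn4)cn3)c(F)c2)C(=O)O1`: 26200 nM

In a physicochemical assay for solubility, read by HPLC, with a stated time of 24 h (a higher number here means a more soluble compound, a lower number a less soluble compound), compound 1 gives 472000 nM. In this assay, going by the values given here, compound 2 gives 26200 nM, the lower of the two numbers in hand; the one change between them is an 18-fold lower number from compound 1 to compound 2 (1.26 log units; beyond the scatter), and this step is the only one in the set that bears on the saturated-ring substituent.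

Compound 3 `CONC(=O)[C@H]1CN(c2ccc(-n3cc(-c4ccccn4)cn3)c(F)c2)C(=O)O1` is not yet measured. It differs from compound 2 in one place: methoxy in place of methyl on an amide-type nitrogen. Among the compounds with values here, no measured pair in this set shows a methyl-to-methoxy exchange on an amide-type nitrogen, so the single step from compound 1 to compound 2 is of a different kind and gives no direct guide to size or direction. With one added hydrogen-bond acceptor and one more heavy atom on the same methylcarbamoyl position, the change is expected to move the number only modestly, and a step of a 1.2-fold higher number from compound 2 to compound 3 (0.09 log units; within the scatter) is expected rather than anything beyond the scatter. On that basis compound 3 is expected to give about 32000 nM in this assay, within a range of 11000 nM to 95000 nM.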

Compound 3, solubility: 78100 nM
Compound 3: middle estimate off by 2.4-fold (0.39 log units), on the low side, and the stated range covers the measured number.
By their numbers in this assay, from the lowest: compound 2; then compound 3; then compound 1.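

In this assay the exchange of methyl for methoxy on the amide-type nitrogen gives a 3.0-fold higher number from compound 2 to compound 3 (0.47 log units; beyond the scatter) and so shows that this nitrogen substituent alone can shift the read-out beyond the scatter, with the rest of the methylcarbamoyl position left as it was. The earlier step, an 18-fold lower number from compound 1 to compound 2 (1.26 log units; beyond the scatter), replaced the whole ((dimethylsulfamoyl)amino)methyl group and could not show this smaller effect. Compound 3 still sits under compound 1, with a 6.0-fold lower number from compound 1 to compound 3 (0.78 log units; beyond the scatter) as the remaining step, so methoxycarbamoyl closes only part of the gap between compound 2 and compound 1, and nothing at hand accounts for either step.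

One exchange on one core cannot show whether the rise belongs to the added oxygen or to the methoxy group as a whole, or whether it would recur elsewhere in the series. Open as well is how the number would respond with the amide hydrogen alone on that nitrogen, with an ethyl group or a longer ethoxy chain there, or with a carboxylic acid in place of the whole carbamoyl group.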